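The source may report more compounds than this note shows. Statements on the series, on what has been measured and on what is new or still open speak of the compounds shown alone.

Of the compounds shown here, three have been measured so far in a physicochemical assay for lipophilicity, at pH 7.4 (a lower number here means a more polar compound, a higher number a more lipophilic compound), as follows.

Compound 1 `N#Cc1ccc(O[C@H]2CN(S(=O)(=O)c3ccccc3C#N)C[C@@]2(O)CO)cc1F` gives 3.4
Compound 2 `N#Cc1ccc(O[C@H]2CN(S(=O)(=O)c3ccc(Cl)cn3)C[C@@]2(O)CO)cc1F` gives 3.4
Compound 3 `N#Cc1ccc(O[C@H]2CN(S(=O)(=O)c3ccc(Cl)cc3)C[C@@]2(O)CO)cc1F` gives 4.1

Compound 3 holds the highest number of the three, and both steps that reach it lie beyond the scatter: a number 0.70 log units higher from compound 1 to compound 3 (beyond the scatter) and a number 0.70 log units higher from compound 2 to compound 3 (beyond the scatter) in this assay terms. By contrast, no change at the digits printed from compound 1 to compound 2 (within the scatter) stays within the scatter.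

The next step leads to compound 4 `N#Cc1ccc(O[C@H]2CN(S(=O)(=O)c3ccc(C(F)(F)F)nc3)C[C@@]2(O)CO)cc1F` and alters only the group on the sulfonyl sulfur: 6-(trifluoromethyl)pyridin-3-yl in place of 4-chlorophenyl on a sulfonyl sulfur. Here 6-(trifluoromethyl)pyridin-3-yl replaces 4-chlorophenyl. The closest evidence is compound 2, with a number 0.70 log units higher from compound 2 to compound 3 (beyond the scatter) as a ring with one hetero atom gives way to a ring of carbon only. The new step runs the opposite way, which points to a lower number for compound 4. However, no measured compound carries a trifluoromethyl group, and the pyridine ring is joined differently, so that earlier step can serve only as a rough guide. A somewhat smaller drop is therefore expected. The estimate is a number 0.40 log units lower from compound 3 to compound 4 (beyond the scatter) and remains an expectation until measured. In this assay the estimated value for compound 4 is 3.7 with an expected range from 3.3 to 4.1 awaiting the measurement.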

Compound 4, distribution coefficient: 4.2
Estimate against measurement, compound 4: 0.50 log units below; measured number outside the range, above it.
By their numbers in this assay, from the lowest: compounds 1 and 2 (each within the scatter of the next); then compounds 3 and 4 (each within the scatter of the next).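

In this assay the step of a number 0.10 log units higher from compound 3 to compound 4 (within the scatter) shows that 6-(trifluoromethyl)pyridin-3-yl and 4-chlorophenyl cannot be told apart on the sulfonyl sulfur, so a ring with one hetero atom at this position need not stay with compound 2. The steps of a number 0.80 log units higher from compound 2 to compound 4 (beyond the scatter) and a number 0.80 log units higher from compound 1 to compound 4 (beyond the scatter) place compound 4 clear of both lower compounds, which means that ring type alone does not sort the four: compound 2 and compound 4 both carry a ring with one hetero atom yet fall on opposite sides, as do compound 1 and compound 3 with their rings of carbon only. Nothing measured here speaks to the reason for this grouping.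

The compounds shown leave open whether the trifluoromethyl group or the way the pyridine ring is joined sets the number of compound 4, as these two features change together in every step to it. They also leave open how this assay would read with an amine or a carboxylic acid on the ring attached to the sulfonyl sulfur.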